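The source may report more compounds than this note shows. Statements on the series, on what has been measured and on what is new or still open speak of the compounds shown alone.

Measured so far in a functional assay on U-87MG ATCC cells (Homo sapiens) for antiproliferative activity, read by MTT assay, with a stated time of 48 h; a lower number here means a stronger inhibitor, a higher number a weaker inhibitor:

Compound 1 `O=C(/C=C\Nc1ccc(C(F)(F)F)cc1)c1cn(-c2ccccc2)nc1-c1ccc(F)cc1` gives > 50000 nM, which is a limit of the assay rather than a number.
Compound 2 `O=C(/C=C\Nc1ccc(O)cc1)c1cn(-c2ccccc2)nc1-c1ccc(F)cc1` gives 4700 nM.
Compound 3 `COc1ccc(-c2nn(-c3ccccc3)cc2C(=O)/C=C\Nc2ccc(C(F)(F)F)cc2)cc1` gives > 50000 nM, again a limit of the assay and not a number.

Compounds 1 and 2 share a core and differ in one place: hydroxy in place of trifluoromethyl on an aromatic carbon. This change produced an at least 10-fold lower number from compound 1 to compound 2 (1.02 log units; beyond the scatter). The cores of compound 1 and compound 3 differ as follows: methoxy in place of fluoro on an aromatic carbon. Between these two the step reads a step that the two limits leave unreadable from compound 1 to compound 3, since both sit at the limit of > 50000 nM in this assay, at which 2 of the 3 values shown sit.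

Compound 4 `COc1ccc(-c2nn(-c3ccccc3)cc2C(=O)/C=C\Nc2ccc(O)cc2)cc1` has not yet been tested in this assay. It relates to compound 3 exactly as compound 2 relates to compound 1: hydroxy in place of trifluoromethyl on an aromatic carbon. The surroundings of the changed position are described in the same words in both cases, so this is the same change carried onto the core of compound 3.

The expectation is that compound 4 will show a step of an at least 7.1-fold lower number from compound 3 to compound 4 (0.85 log units; beyond the scatter), resting on the earlier at least 10-fold lower number from compound 1 to compound 2 (1.02 log units; beyond the scatter) seen when the same change was made on compound 1. Because compound 3 sits at the limit of > 50000 nM in this assay, at which 2 of the 3 values shown sit, the starting point of this step is itself unknown, and the estimate is therefore wide. Compound 4 is expected to reach about 7000 nM in this assay, estimated to lie between 1500 nM and 40000 nM.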

Compound 4, half-maximal inhibitory concentration: 3730 nM
Estimate against measurement, compound 4: 1.9-fold (0.27 log units) above; the measured number falls inside the stated range.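

In this assay, putting hydroxy in place of trifluoromethyl on the core of compound 3 gives an at least 13-fold lower number from compound 3 to compound 4 (1.12 log units; beyond the scatter), so the change carries over to this second core in the same direction and is large on both, but the two sizes cannot be compared exactly: the same change on two cores in this assay, an at least 10-fold lower number (1.02 log units; beyond the scatter) from compound 1 to compound 2 and an at least 13-fold lower number (1.12 log units; beyond the scatter) from compound 3 to compound 4; the limit leaves it open whether they differ. As far as these compounds go, compound 3 gives > 50000 nM, which is a limit of the assay and not a number, so the true size of its step stays unknown. With hydroxy present on both cores, methoxy in place of fluoro gives a 1.3-fold lower number from compound 2 to compound 4 (0.10 log units; within the scatter), which leaves compound 2 and compound 4 indistinguishable in this assay, while the step between the two trifluoromethyl compounds cannot be read and the exact size of the hydroxy change remains unfixed on either core: the limit of > 50000 nM in this assay, at which 2 of the 4 values shown sit.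

From the compounds shown here alone, only trifluoromethyl and hydroxy appear at this position on the aromatic ring, so it remains open whether a plain hydrogen, an amine or a carboxylic acid there would give numbers nearer to those of the hydroxy compounds or to the limit. Among these compounds, the change has also been followed on only two cores, so whether it carries over when a group such as a chloro or a longer chain replaces the fluoro or methoxy remains open as well.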